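Benzylidene hydrazides: moving the trifluoromethyl group on the arylidene

This account rests on a few compounds, and the source may have more. Where it says the series, first, only, none or still open, it means among the compounds named here.

Measured compounds:
compound 1 `CN(C(=O)NC(=O)c1ccc(Cl)cc1Cl)c1nc(C(F)(F)F)c(C(=O)N/N=C/c2cccc(C(F)(F)F)c2)s1`, 10.7 ug/mL
compound 2 `CN(C(=O)NC(=O)c1c(F)cccc1F)c1nc(C(F)(F)F)c(C(=O)N/N=C/c2cccc(C(F)(F)F)c2)s1`, 21.8 ug/mL
compound 3 `CN(C(=O)NC(=O)c1ccc(C(F)(F)F)cc1)c1nc(C(F)(F)F)c(C(=O)N/N=C/c2ccc(C(F)(F)F)cc2)s1`, > 100 ug/mL (a limit)

Within the data shown here, in a functional assay on MCF7 cells (Homo sapiens) for inhibition, read by MTT assay, with a stated time of 72 h (on this read-out lower numbers stand for stronger inhibition and higher numbers for weaker inhibition), compound 1 gives a number, as does compound 2; the one measured step is a 2.0-fold higher number from compound 1 to compound 2 (0.31 log units; beyond the scatter), a change at the acyl group only. For compound 3 this assay reports only a limit, > 100 ug/mL, at the limit of > 100 ug/mL in this assay, at which 1 of the 3 values shown sits; its standing on the numbers is therefore unknown. Compound 4 `CN(C(=O)NC(=O)c1ccc(C(F)(F)F)cc1)c1nc(C(F)(F)F)c(C(=O)N/N=C/c2cccc(C(F)(F)F)c2)s1` differs from compound 3 by 3-(trifluoromethyl)phenyl in place of 4-(trifluoromethyl)phenyl on a carbon with a double bond to nitrogen. Among the measured compounds shown here, no measured step addresses this change, so its size cannot be read from the data. Compounds 1 and 2, which carry 3-(trifluoromethyl)phenyl on the same carbon, return numbers in this assay; compound 4 is expected to do likewise, the expected step being an at least 2.5-fold lower number from compound 3 to compound 4 (0.39 log units; beyond the scatter). The estimate for compound 4 is 40 ug/mL, between 10 ug/mL and 100 ug/mL.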

Compound 4, half-maximal inhibitory concentration: 8.95 ug/mL
The estimate for compound 4 lay 4.5-fold (0.65 log units) above the measured number, and the stated range ends above it.
By their numbers in this assay, from the lowest: compounds 4 and 1 (each within the scatter of the next); then compound 2. At a limit, above all of these: compound 3.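

In this assay, 3-(trifluoromethyl)phenyl in place of 4-(trifluoromethyl)phenyl on the carbon with a double bond to nitrogen gives an at least 11-fold lower number from compound 3 to compound 4 (1.04 log units; beyond the scatter), so this place in the series is sensitive to an isomeric change that leaves the atoms unchanged. The size of this step remains a bound, as compound 3 has only a limit: the limit of > 100 ug/mL in this assay, at which 1 of the 4 values shown sits. With 3-(trifluoromethyl)phenyl held, changing the acyl aryl group gives a 2.4-fold lower number from compound 2 to compound 4 (0.39 log units; beyond the scatter) and a 1.2-fold lower number from compound 1 to compound 4 (0.08 log units; within the scatter), a much smaller range.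

As far as these compounds go, whether 4-(trifluoromethyl)phenyl on that carbon is as poor with 2,4-dichlorophenyl or 2,6-difluorophenyl on the carbonyl carbon remains open. So does the effect of replacing the trifluoromethyl group of the arylidene with a nitrile or a carboxylic acid.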